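Losing the 3-methylbut-2-en-1-yl Group: Compound 4 Awaited

The compounds below may be only part of what the source reports. "The series", "measured", "known", "first", "only" and "open" are said of these compounds alone.

Three compounds have been measured in a functional assay on A549 cells (Homo sapiens) for inhibition, read by MTT assay, with a stated time of 72 h; on this read-out higher numbers stand for weaker inhibition and lower numbers for stronger inhibition:

Compound 1 `COc1ccc(/C=C/C(=O)c2c(OC)cc(O)c(CC=C(C)C)c2O)cc1` gives 38000 nM.
Compound 2 `COc1ccccc1/C=C/C(=O)c1c(OC)cc(O)c(CC=C(C)C)c1O` gives 12500 nM.
Compound 3 `COc1ccc(/C=C/C(=O)c2c(O)cc(O)cc2OC)cc1` gives only a limit, > 50000 nM.

Compound 1 and compound 2 share their atoms but join them differently: 2-methoxyphenyl in place of 4-methoxyphenyl on a double-bonded chain carbon bound to a double-bonded chain carbon. In this assay the step is a 3.0-fold lower number from compound 1 to compound 2 (0.48 log units; beyond the scatter), so compound 2 holds the lowest of the two real numbers, and the third value is a limit.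

Compound 3 differs from compound 1 by hydrogen in place of 3-methylbut-2-en-1-yl on an aromatic carbon. The step of an at least 1.3-fold higher number from compound 1 to compound 3 (0.11 log units; that floor lies within the scatter) is only a floor, since compound 3 sits at the limit of > 50000 nM in this assay, at which 1 of the 3 values shown sits; the true size of the step is not known.

Compound 4 `COc1ccccc1/C=C/C(=O)c1c(O)cc(O)cc1OC` has not yet been measured in this assay. It differs from compound 2 by hydrogen in place of 3-methylbut-2-en-1-yl on an aromatic carbon, the same change that took compound 1 to compound 3, made at a place described in the same words. The earlier step gave no number on the far side, so the expectation for compound 4 rests on compound 2 at 12500 nM and on the direction of an at least 1.3-fold higher number from compound 1 to compound 3 (0.11 log units; that floor lies within the scatter). Compound 4 is expected to give a higher number than compound 2, a step estimated at a 2.4-fold higher number from compound 2 to compound 4 (0.38 log units; beyond the scatter). The estimate for compound 4 is 30000 nM, between 12000 nM and 80000 nM, with a real chance that the assay reports only a limit.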

Compound 4, half-maximal inhibitory concentration: 47700 nM
Estimate against measurement, compound 4: 1.6-fold (0.20 log units) below; measured number inside the range.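

Putting hydrogen in place of 3-methylbut-2-en-1-yl on an aromatic carbon now has a measured size on one core in this assay: a 3.8-fold higher number from compound 2 to compound 4 (0.58 log units; beyond the scatter). Compound 3 gives > 50000 nM, which is a limit and not a number, so the same change on the core of compound 1 is known only as a floor. The series therefore shows that the change costs a step beyond the scatter on the core carrying the 2-methoxyphenyl group, but it does not show whether the step is equal, larger or smaller on the core carrying the 4-methoxyphenyl group, and the size found here cannot simply be carried across: the same change on two cores in this assay, an at least 1.3-fold higher number (0.11 log units; that floor lies within the scatter) from compound 1 to compound 3 and a 3.8-fold higher number (0.58 log units; beyond the scatter) from compound 2 to compound 4; the limit leaves it open whether they differ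

The compounds shown leave open whether the effect belongs to the 3-methylbut-2-en-1-yl group in particular, as only hydrogen stands in its place here, and a saturated 3-methylbutyl chain, a simple methyl group or a longer chain such as geranyl would speak to that. From the compounds shown here alone, it also remains open how the series would read with a hydroxy group or a chlorine atom in place of the methoxy group on the phenyl ring.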